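A few compounds are considered here, and "the series" means these few. Any claim that something is new, unique, unknown or untested is made for them only; others in the source may bear on it.

In a functional assay on MCF7 cells (Homo sapiens) for cytotoxicity, read by fluorescence, with a stated time of 72 h (on this read-out higher numbers stand for weaker inhibition and lower numbers for stronger inhibition), compound 1 (`Nc1nn(C(=O)c2ccc([N+](=O)[O-])cc2)c(N)c1/N=N/c1ccc(O)cc1`) gives > 25000 nM as a limit and not as a number. Compound 2 (`Nc1n[nH]c(N)c1/N=N/c1cccc[n+]1[O-]`) gives > 100000 nM as a limit too. Compound 3 (`Nc1n[nH]c(N)c1/N=N/c1cc[n+]([O-])cc1`) gives > 100000 nM as a limit too. Compound 1 therefore stands on a limit only, among readings that are all limits, and no two of these compounds differ in one place. Compound 4 (`CC(=O)n1nc(N)c(/N=N/c2ccc(O)cc2)c1N`) carries methyl in place of 4-nitrophenyl on a carbonyl carbon and is otherwise the same as compound 1. In this assay the expected step (a step that the limit leaves unreadable from compound 1 to compound 4) is none beyond the usual scatter, with no direction favoured. Compound 4 is estimated at 40000 nM with an expected range of 15000 nM to 100000 nM and may well return only a limit.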

Compound 4, half-maximal inhibitory concentration: 44900 nM
For compound 4 the middle estimate is 1.1-fold (0.05 log units) below the measured one, and the stated range covers the measured number.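

Among the compounds shown here, compound 1 gives > 25000 nM, a limit and not a number, and no step to compound 4 can be read from it. The compounds shown leave open whether methyl or 4-nitrophenyl on the carbonyl carbon gives stronger inhibition in this assay.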